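Sulfonyl substituent swap in the agonist series

A few compounds are considered here, and "the series" means these few. Any claim that something is new, unique, unknown or untested is made for them only; others in the source may bear on it.

Two compounds of the series carry measurements. Compound 1 `Cc1ccc2[nH]c(C(=O)N[C@H]3CN(S(=O)(=O)C4CCOCC4)C[C@@H]3C(=O)NCCN(C)C)cc2c1` in a functional assay on HEK293 cells for agonist activity at growth hormone secretagogue receptor type 1 (Homo sapiens), read by HTRF and inositol phosphate accumulation, with a stated time of 90 min, in the presence of a further agent that is not named here (a higher number here means a larger maximal response, a lower number a smaller maximal response), gives 90%. Compound 2 `Cc1ccc2[nH]c(C(=O)N[C@H]3CCN(S(=O)(=O)c4cccnc4)C[C@@H]3C(=O)NCCN(C)C)cc2c1` in this assay gives 93%. Among the measured compounds shown here, compound 2 stands with compound 1 within the scatter of repeated measurements, so the two are not set apart from one another, and no step between measured compounds is available in this set.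

Compound 3 `Cc1ccc2[nH]c(C(=O)N[C@H]3CCN(S(=O)(=O)N4CCCCC4)C[C@@H]3C(=O)NCCN(C)C)cc2c1` has not yet been measured in this assay. It differs from compound 2 in one place: piperidin-1-yl in place of pyridin-3-yl on a sulfonyl sulfur. Both measured compounds give a maximal response close to the control, and the change does not touch the rest of the shared core. For the step from compound 2 to compound 3 the expectation is therefore no change beyond the scatter, at most a small drift downward, as a number 5 percentage points lower from compound 2 to compound 3 (within the scatter). Compound 3 in this assay is estimated at 88%, with a range from 70% to 102%.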

Compound 3, largest response reached (Emax), in percent of the reference or control that the assay uses: 105%
Compound 3: the middle estimate sits 17 percentage points below what was measured; the measured number lies above the stated range.
By their numbers in this assay, from the lowest: compounds 1 and 2 (each within the scatter of the next); then compound 3.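

On a sulfonyl sulfur whose other neighbours are the sulfonamide nitrogen in a ring, this position is not indifferent to the group it carries: in this assay the change gives a number 12 percentage points higher from compound 2 to compound 3 (beyond the scatter) and lifts the series out of the narrow band seen so far. Both groups hold 6 heavy atoms, 5 carbon and 1 nitrogen, so the step goes with a six-membered aromatic ring becoming a non-aromatic one and with hydrogen-bond acceptors going from 1 to 0, and these two differences cannot be told apart here. Nothing available bears on the reason for the step.

Open, on these data alone, is whether cyclohexyl or phenyl on the same sulfur would separate the ring type from the nitrogen bound to sulfur. Also open, as far as these compounds go, is whether morpholin-4-yl or an open-chain dimethylamino group would follow piperidin-1-yl.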